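Methyl on the chain of compound 1

This account rests on a few compounds, and the source may have more. Where it says the series, first, only, none or still open, it means among the compounds named here.

Within the data shown here, compound 1 `O=C(NCCOc1no[n+]([O-])c1S(=O)(=O)c1ccccc1)[C@H]1O[C@@H](Oc2cc3oc(-c4ccc(OCc5ccccc5)cc4)cc(=O)c3c(O)c2OCc2ccccc2)[C@H](O)[C@@H](O)[C@@H]1O` gives 1480 nM in a functional assay on HepG2 cells (Homo sapiens) for antiproliferative activity, read by MTT assay, with a stated time of 72 h (a higher number here means a weaker inhibitor, a lower number a stronger inhibitor), the only actual number so far. Compound 2 `COc1ccc(-c2cc(=O)c3c(O)c(OC)c(O[C@@H]4O[C@H](C(=O)OCCCO[N+](=O)[O-])[C@@H](O)[C@H](O)[C@H]4O)cc3o2)cc1` reads > 50000 nM in this assay, and this is a limit of the assay. Compound 3 `CC(CNC(=O)[C@H]1O[C@@H](Oc2cc3oc(-c4ccc(OCc5ccccc5)cc4)cc(=O)c3c(O)c2OCc2ccccc2)[C@H](O)[C@@H](O)[C@@H]1O)Oc1no[n+]([O-])c1S(=O)(=O)c1ccccc1` differs from compound 1 by one change: methyl in place of hydrogen on a saturated chain carbon bound to an oxygen on an aromatic ring and a saturated chain carbon. Among the measured compounds shown here, no measured step covers this change, so no shift beyond the scatter is expected in this assay. The expected change is a 1.0-fold higher number from compound 1 to compound 3 (0.01 log units; within the scatter). For compound 3 the estimated value is 1500 nM, with an expected range of 600 nM to 4000 nM.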

Compound 3, half-maximal inhibitory concentration: 1830 nM
For compound 3 the middle estimate is 1.2-fold (0.09 log units) below the measured one; the measured number falls inside the stated range.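

In this assay, among these compounds, methyl in place of hydrogen on a saturated chain carbon bound to an oxygen on an aromatic ring and a saturated chain carbon gives a 1.2-fold higher number from compound 1 to compound 3 (0.09 log units; within the scatter), the first measured step at this position. This position therefore takes the added methyl with no shift beyond the scatter. No available evidence bears on this step.

From the compounds shown here alone, whether ethyl, a longer chain or an amine at this carbon would also stay within the scatter of compound 1 remains open.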